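A few compounds are considered here, and "the series" means these few. Any claim that something is new, unique, unknown or untested is made for them only; others in the source may bear on it.

Within the data shown here, in a physicochemical assay for solubility, read by spectrophotometry, in phosphate buffer, with a stated time of 18 h, at pH 7.4 (on this read-out lower numbers stand for lower solubility and higher numbers for higher solubility), compound 1 (`CCc1ccc(-c2nc3c(c(C)nn3-c3ccccc3)c(-c3ccccc3O)c2C#N)cc1`) gives 3100 nM and stands lowest of the two numbers so far. Among the measured compounds shown here, the only other measured compound, compound 2 (`CCc1ccc(-c2nc3c(c(C)nn3-c3ccccc3)c(-c3ccccc3C(=O)OC)c2C#N)cc1`), gives 17000 nM on the same read-out. Compound 3 (`CCc1ccc(-c2nc3c(c(C)nn3-c3ccc(C)cc3)c(-c3ccccc3O)c2C#N)cc1`) keeps the core of compound 1 and differs at one place (methyl in place of hydrogen on an aromatic carbon), with methyl in place of hydrogen on an aromatic carbon, so that phenyl becomes 4-methylphenyl. For the measured compounds named here, the one measured step (a 5.5-fold higher number from compound 1 to compound 2 (0.74 log units; beyond the scatter)) is modest, but it is methoxycarbonyl in place of hydroxy, a different change at a different place, so it offers little guidance here. Going by the values given here, no measured pair shows the effect of adding this methyl. In this assay only a small step is therefore expected, within the scatter and, if anything, towards a lower number. The expected step (a 1.3-fold lower number from compound 1 to compound 3 (0.13 log units; within the scatter)) is an estimate with wide margins. The estimated value for compound 3 is 2300 nM and it is expected to fall between 800 nM and 6000 nM in four of five measurements.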

Compound 3, solubility: 8900 nM
Compound 3: the middle estimate sits 3.9-fold (0.59 log units) below what was measured; measured number above the stated range.
By their numbers in this assay, from the lowest: compound 1; then compounds 3 and 2 (each within the scatter of the next).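

In this assay, the single added methyl that turns phenyl into 4-methylphenyl gives a 2.9-fold higher number from compound 1 to compound 3 (0.46 log units; beyond the scatter) on an otherwise unchanged molecule. Among these compounds, the earlier pair changed only the hydroxy group, so this is the first reading at this other place, on an aromatic carbon para to a large group, and it shows that one added carbon here can move the number upward beyond the usual scatter. Nothing in the data shown bears on what lies behind this rise.

Going by these compounds, whether the rise is particular to methyl stays open, as a methoxy group, a chlorine atom, an amine or a longer chain such as ethyl at the same place would be needed to tell. Also open, on these data alone, is whether the same methyl would move the number similarly in compound 2, which carries methoxycarbonyl in place of hydroxy.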